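The compounds below may be only part of what the source reports. "The series", "measured", "known", "first", "only" and "open" are said of these compounds alone.

Of the compounds shown here, three have been measured so far in a functional assay on Jurkat cells (Homo sapiens) for inhibition, read by CCK-8 assay, with a stated time of 48 h; a higher number here means a weaker inhibitor of growth, a lower number a stronger inhibitor of growth. Compound 1 (`Cc1ccccc1Nc1nc(Nc2cccnc2)ncc1Cl`) gives 38600 nM, compound 2 (`Cc1ccccc1Nc1nc(Nc2ccccn2)ncc1Cl`) gives 20100 nM, and compound 3 (`CN1CCN(c2ccc(Nc3ncc(Cl)c(NCc4ccc(C(F)(F)F)cc4)n3)nc2)CC1`) gives 7960 nM. Compound 3 has the lowest number of the three, and its gaps to both others lie beyond the scatter.

The next structure is compound 4 (`Cc1ccc(Nc2nc(Nc3ccc(N4CCN(C)CC4)cn3)ncc2Cl)cc1`), with 4-methylphenyl in place of 4-(trifluoromethyl)benzyl on a nitrogen on an aromatic ring.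

Among the measured compounds shown here, only one measured step is available for comparison, a 1.9-fold lower number from compound 1 to compound 2 (0.28 log units; within the scatter). It swaps pyridin-3-yl for pyridin-2-yl, not the group that changes here, so it bears on this change only weakly. It does show that one small swap can leave the number within the scatter. For the measured compounds named here, no measured pair isolates the present swap, so the direction remains open.

The expected change, a 1.1-fold lower number from compound 3 to compound 4 (0.06 log units; within the scatter), is no step beyond the scatter. For compound 4 the estimated value is 7000 nM, with an expected range from 2200 nM to 22000 nM.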

Compound 4, concentration for 50% growth inhibition: 30900 nM
Estimate against measurement, compound 4: 4.4-fold (0.64 log units) below; the whole stated range lies below it.
By their numbers in this assay, from the lowest: compound 3; then compounds 2, 4 and 1 (each within the scatter of the next).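

In this assay the swap to 4-methylphenyl gives a 3.9-fold higher number from compound 3 to compound 4 (0.59 log units; beyond the scatter) and so shows that the group on this nitrogen on an aromatic ring can shift the number beyond the scatter. Both groups carry one six-membered aromatic ring of carbon only, so a change that keeps this ring can still move the result, even though the entering group has fewer heavy atoms and no fluorine. Nothing measured here explains why the number rises.

The swap alters the trifluoromethyl end and the benzyl form of the group together, so the compounds shown cannot assign the step to either change. From the compounds shown here alone, a 4-methylbenzyl or a 4-(trifluoromethyl)phenyl group on this nitrogen would separate the two, and how either would read remains open.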